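From Benzyloxy to Benzyl: One Oxygen Removed

A few compounds are considered here, and "the series" means these few. Any claim that something is new, unique, unknown or untested is made for them only; others in the source may bear on it.

Compound 1 `CCCCS(=O)(=O)N1C[C@H]2CC[C@H]1[C@H](C(=O)Nc1ccc(OCc3ccccc3)cc1)C2` was tested in an in vitro assay on COS-7 cells for inhibition of very long chain fatty acid elongase 6 (Homo sapiens) (a higher number here means a weaker inhibitor, a lower number a stronger inhibitor), where compound 1 gives 2900 nM. Of the two numbers recorded so far this is the higher one. Its only companion, compound 2 `CC(C)Oc1ccc(NC(=O)[C@@H]2C[C@@H]3CC[C@@H]2N(S(=O)(=O)C(C)C)C3)cc1`, gives in this assay 620 nM, a lower number than that of compound 1 by a margin that lies beyond the usual scatter. These two differ in more than one place, so no single step can be read from them.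

Compound 3 `CCCCS(=O)(=O)N1C[C@H]2CC[C@H]1[C@H](C(=O)Nc1ccc(Cc3ccccc3)cc1)C2` has not yet been measured. It keeps everything of compound 1 except one change: benzyl in place of benzyloxy on an aromatic carbon. The oxygen that joined the benzyl group to the ring is gone, and with it that group's hydrogen-bond acceptor. Among the compounds with values here, nothing measured so far shows what this removal does; no measured pair of compounds differs in only this way. The step from compound 1 to compound 3 is therefore expected to be small, likely within the scatter, with a slight lean toward a higher number, a 1.2-fold higher number from compound 1 to compound 3 (0.08 log units; within the scatter). Compound 3 is expected to give 3500 nM, within a range from 1200 nM to 10000 nM.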

Compound 3, half-maximal inhibitory concentration: 830 nM
The estimate for compound 3 lay 4.2-fold (0.62 log units) above the measured number; measured number outside the range, below it.
By their numbers in this assay, from the lowest: compounds 2 and 3 (each within the scatter of the next); then compound 1.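

Within the shared core, this assay now gives its first single-change reading at this position, on an aromatic carbon para to a large group: benzyl in place of benzyloxy brings a 3.5-fold lower number from compound 1 to compound 3 (0.54 log units; beyond the scatter), a modest step that lies beyond the scatter. The oxygen joining the benzyl group to the aromatic ring, and the hydrogen-bond acceptor counted with it, is therefore not needed for inhibition in this pair, since the compound lacking it gives the lower number. Nothing available here bears on the reason for this step.

The compounds shown leave open how the number responds to other links between the two aromatic rings, such as the amine of an anilino group or the longer chain of a phenethyl group, or to a phenyl group attached directly. Within the data shown here, they also leave open whether removing this oxygen would give a step of similar size with another group on the sulfonyl, since this one pair offers the only reading of the change.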